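Fluoro in Place of Methoxy: Expectation for Compound 3

The source may report more compounds than this note shows. Statements on the series, on what has been measured and on what is new or still open speak of the compounds shown alone.

Of the compounds shown here, two have been measured in a functional assay on C6 cells (Rattus norvegicus) for cytotoxicity, read by MTT assay, with a stated time of 24 h, tested at 6 ug/mL; on this read-out higher numbers stand for a weaker effect at the one concentration tested and lower numbers for a stronger effect. Compound 1, `O=C(CSc1nnnn1-c1ccccc1)N/N=c1/scc(-c2ccc(F)cc2)n1-c1ccccc1`, gives 74.9% in this assay. Compound 2, `COc1ccc(-c2cs/c(=N/NC(=O)CSc3ncccn3)n2-c2ccccc2)cc1`, gives 89.6% in this assay, the higher of the two numbers, and its gap to compound 1 lies beyond the usual scatter. The next compound, compound 3, `O=C(CSc1ncccn1)N/N=c1/scc(-c2ccc(F)cc2)n1-c1ccccc1`, differs from compound 2 in one place: fluoro in place of methoxy on an aromatic carbon. Among the measured compounds shown here, no step between two measured compounds isolates this change, since compound 1 and compound 2 differ elsewhere as well. Because compound 1 carries fluoro in this position and gives 74.9%, a downward step from compound 2 is expected, though one that may still fall near the scatter. The expected step from compound 2 to compound 3 is estimated as a number 8.6 percentage points lower from compound 2 to compound 3 (within the scatter). Compound 3 is therefore expected to give about 81% in this assay, with a range from 66% to 95%.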

Compound 3, a percentage reported as activity, at one concentration (the size of the read-out at that concentration, not a potency): 84%
Beside the measured number, compound 3's estimate is 3 percentage points below it; measured number inside the range.
By their numbers in this assay, from the lowest: compounds 1, 3 and 2 (each within the scatter of the next, the first and the last beyond it).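

In this assay, among the compounds shown here, fluoro in place of methoxy, on an aromatic carbon para to a large group, gives a number 5.6 percentage points lower from compound 2 to compound 3 (within the scatter) and so provides the first reading of this change on its own. With the 4-fluorophenyl kept, pyrimidin-2-yl in place of 1-phenyl-1H-tetrazol-5-yl on the sulfur gives a number 9.1 percentage points higher from compound 1 to compound 3 (within the scatter) and thus shows that neither single change, taken alone, leaves the scatter. Nothing available here accounts for the size of either step.

The compounds shown leave open how an amine or a carboxylic acid in place of fluoro on this aromatic carbon would read in this assay at the one concentration tested. They also leave open whether fluoro in place of methoxy would give a similar step with 1-phenyl-1H-tetrazol-5-yl on the sulfur.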